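Swapping the group on the ring nitrogen

This account rests on a few compounds, and the source may have more. Where it says the series, first, only, none or still open, it means among the compounds named here.

compound 1 `O=C(c1cccc(Cl)c1)N1CCC(NS(=O)(=O)c2cc(S(=O)(=O)c3ccccc3)ccc2C(F)(F)F)CC1` – 6300 nM
compound 2 `O=C(c1ccc(Cl)cc1)N1CCC(NS(=O)(=O)c2cc(S(=O)(=O)c3ccccc3)ccc2C(F)(F)F)CC1` – 3100 nM
compound 3 `O=C(c1ccc(Cl)nc1)N1CCC(NS(=O)(=O)c2cc(S(=O)(=O)c3ccccc3)ccc2C(F)(F)F)CC1` – 25000 nM

These numbers come from a physicochemical assay for solubility (a higher number here means a more soluble compound, a lower number a less soluble compound), and compound 3 stands highest of the three, with its steps to both others beyond the scatter. Compound 4 `O=C(O)c1cccc(S(=O)(=O)N2CCC(NS(=O)(=O)c3cc(S(=O)(=O)c4ccccc4)ccc3C(F)(F)F)CC2)c1` is not yet measured. It carries (3-carboxyphenyl)sulfonyl in place of (6-chloropyridin-3-yl)carbonyl on an amine nitrogen in a ring.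

The measured steps bear on this only loosely, as each one merely exchanges the ring on a carbonyl carbon. They are modest (a 2.0-fold lower number from compound 1 to compound 2 (0.31 log units; beyond the scatter); a 4.0-fold higher number from compound 1 to compound 3 (0.60 log units; beyond the scatter); an 8.1-fold higher number from compound 2 to compound 3 (0.91 log units; beyond the scatter)). None of them replaces the carbonyl with a sulfonyl or brings in a carboxyl, so the direction remains a tentative judgement. A step of similar modest size in this assay is expected, leaning slightly upward. The expected step is small and uncertain (a 2.0-fold higher number from compound 3 to compound 4 (0.30 log units; within the scatter)). For compound 4 the estimated value is 50000 nM with an expected range from 10000 nM to 150000 nM as its limits.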

Compound 4, solubility: 12500 nM
Beside the measured number, compound 4's estimate is 4.0-fold (0.60 log units) above it, and the stated range covers the measured number.
By their numbers in this assay, from the lowest: compound 2; then compounds 1, 4 and 3 (each within the scatter of the next, the first and the last beyond it).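

Moving from a carbonyl to a sulfonyl link on the amine nitrogen in a ring, and adding a carboxyl group, alters more than the ring swaps among compounds 1 to 3 did, yet this assay shows a 2.0-fold lower number from compound 3 to compound 4 (0.30 log units; within the scatter) for this exchange. Among the compounds shown here, the comparison with the 3-chlorophenyl amide gives a 2.0-fold higher number from compound 1 to compound 4 (0.30 log units; within the scatter) and so also stays inside the scatter, while the comparison with the 4-chlorophenyl amide gives a 4.0-fold higher number from compound 2 to compound 4 (0.61 log units; beyond the scatter) as the only new step beyond it. This position therefore accepts a quite different group with a number that stays inside the span of the carbonyl compounds, though nothing available explains these numbers.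

From the compounds shown here alone, compound 4 changes the link and the carboxyl group together, so their separate contributions remain open. A (3-carboxyphenyl)carbonyl group or a plain phenylsulfonyl group on this nitrogen would pull the two apart.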